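This account rests on a few compounds, and the source may have more. Where it says the series, first, only, none or still open, it means among the compounds named here.

The measured compounds, with the numbers they give in a physicochemical assay for lipophilicity, read by HPLC, measured as chromatographic lipophilicity, at pH 7.4; on this read-out higher numbers stand for higher lipophilicity and lower numbers for lower lipophilicity:

Compound 1 `O=C(c1ccccc1)N1CCC(C(=O)N2N=CCC2c2ccccc2)CC1` gives 4.4.
Compound 2 `Cc1nnc(N2CCC(C(=O)N3N=CC[C@H]3c3ccccc3)CC2)o1` gives 3.2.
Compound 3 `CC1=NN(C(=O)C(C)(C)C)[C@H](c2ccccc2)C1` gives 6.4.

Among these three numbers, compound 1 stands second highest. Its nearest neighbour is compound 2, whose number lies lower by more than the usual scatter of repeated measurements; compound 3 lies furthest away, with a number higher than that of compound 1 by well more than the scatter. No two of the measured compounds differ from each other in only one place, so no single structural change has yet been paired with a measured step in this assay.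

Compound 4 `O=C(c1cc[nH]n1)N1CCC(C(=O)N2N=CCC2c2ccccc2)CC1` is the next to be measured. It differs from compound 1 in a single place: 1H-pyrazol-3-yl in place of phenyl on a carbonyl carbon. Among the measured compounds shown here, with no measured step of the same kind to lean on, the expectation rests on the structures alone. The step of a number 1.60 log units lower from compound 1 to compound 4 (beyond the scatter) is expected to be downward and clearly beyond the scatter. Compound 4 is therefore estimated to come out at 2.8, with a likely range from 2.2 to 3.4.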

Compound 4, distribution coefficient: 2.4
Estimate against measurement, compound 4: 0.40 log units above, within the range that was stated.
By their numbers in this assay, from the lowest: compound 4; then compound 2; then compound 1; then compound 3.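

In this assay, putting 1H-pyrazol-3-yl in place of phenyl on a carbonyl carbon gives a number 2.00 log units lower from compound 1 to compound 4 (beyond the scatter). Among the compounds shown here, this is the first change in the set that can be tied to a single place, and it shows that the read-out responds strongly to the group on this carbonyl carbon. The entering ring has one atom fewer than phenyl, contains two nitrogens and counts one hydrogen-bond donor and one acceptor, but nothing at hand shows which of these differences matters for the step.

As far as these compounds go, a group such as 1-methyl-1H-pyrazol-3-yl, with a methyl group on the ring nitrogen in place of its hydrogen, could help separate these differences, but its effect here remains open. For the compounds shown here, whether the same exchange gives a step of similar size on another core also remains open, with only this one pair to go on.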